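The compounds below may be only part of what the source reports. "The series", "measured", "known", "first", "only" and "open" are said of these compounds alone.

Measured compounds:
compound 1, `COc1ccc(-c2cc(/C=C/C(=O)c3ccc(N)cc3)[nH]n2)cc1`, in a functional assay on HCT-15 cells (Homo sapiens) for cytotoxicity, read by sulforhodamine B assay, with a stated time of 48 h, tested at 1 uM (a lower number here means a stronger effect, a higher number a weaker effect of the compound at the concentration tested), compound 1 gives 50%
compound 2, `COc1cc(-c2cc(/C=C/C(=O)c3ccc(N)cc3)[nH]n2)cc(OC)c1OC`, in this assay compound 2 gives 60%

Compound 2 carries the number at the upper end of the two measured, but the gap to compound 1 lies within the usual scatter of such measurements, so the two compounds cannot be told apart on these numbers. Within the data shown here, no step between the two measured compounds has been worked out; they differ in more than one place.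

Compound 3, `COc1cc(-c2cc(/C=C/C(=O)c3ccc(F)c(F)c3)[nH]n2)cc(OC)c1OC`, has not yet been measured. It differs from compound 2 in a single place: 3,4-difluorophenyl in place of 4-aminophenyl on a carbonyl carbon. Among the measured compounds shown here, nothing among the measured compounds shows what this exchange does, since neither bears a difluorophenyl group. For the measured compounds named here, with no comparable step to rest on, the expectation is that the number stays near that of compound 2, with a step of a number 8 percentage points lower from compound 2 to compound 3 (within the scatter), not beyond the scatter in either direction. Compound 3 is therefore estimated at 52%, within a range from 25% to 80%.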

Compound 3, a percentage reported as activity, at one concentration (the size of the read-out at that concentration, not a potency): 88%
Estimate against measurement, compound 3: 36 percentage points below, and the stated range ends below it.
By their numbers in this assay, from the lowest: compounds 1 and 2 (each within the scatter of the next); then compound 3.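

The exchange of 4-aminophenyl for 3,4-difluorophenyl on a carbonyl carbon gives, in this assay, a number 28 percentage points higher from compound 2 to compound 3 (beyond the scatter) and so a weaker effect at the concentration tested. Among these compounds, this is the first sign that the group on this carbonyl carbon matters, as compound 1 and compound 2 both carry 4-aminophenyl there and could show nothing about this place. No measurement at hand accounts for the change.

From the compounds shown here alone, it remains open whether the amine or the two fluorines drive the step, and plain phenyl, 4-fluorophenyl or 4-dimethylaminophenyl on the same carbon would help separate the two. Going by these compounds, it is also open whether the same exchange would give a step of similar size on the core of compound 1.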